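The compounds below may be only part of what the source reports. "The series", "measured", "known", "first", "only" and "open" are said of these compounds alone.

Compound 1 `CCCCCCC(CCO)n1cnc2c(NC)ncnc21`: > 50000 nM (a limit)
Compound 2 `CCCCCCC(CCO)n1cnc2cncnc21`: > 50000 nM (a limit)
Compound 3 `CCCCCCCCCCC(CCO)n1cnc2c(NC)ncnc21`: not yet measured

In a functional assay on HCT-116 cells (Homo sapiens) for antiproliferative activity, read by MTT assay, with a stated time of 48 h (on this read-out lower numbers stand for stronger inhibition and higher numbers for weaker inhibition), compound 1 stands only at a limit, > 50000 nM. Both measured compounds sit there: the limit of > 50000 nM in this assay, at which 2 of the 2 values shown sit. The change to compound 3 is butyl in place of hydrogen on a saturated chain carbon, seven bonds along the chain from an aromatic nitrogen. Within the data shown here, the one measured step, a step that the two limits leave unreadable from compound 1 to compound 2, lies at a different place, so no measured size bears on this change. A modest move toward stronger inhibition is expected in this assay, though a result at the limit remains quite possible. The expected step is an at least 2.0-fold lower number from compound 1 to compound 3 (0.30 log units; that floor lies within the scatter). For compound 3 the estimated value is 25000 nM, with an expected range of 7000 nM to 70000 nM.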

Compound 3, half-maximal inhibitory concentration: 12700 nM
Estimate against measurement, compound 3: 2.0-fold (0.29 log units) above; the range from low to high includes it.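

In this assay, butyl in place of hydrogen on a saturated chain carbon, seven bonds along the chain from an aromatic nitrogen, gives an at least 3.9-fold lower number from compound 1 to compound 3 (0.59 log units; beyond the scatter). This is the one readable step in the series, and it shows that change at this position can bring a compound off the limit: the limit of > 50000 nM in this assay, at which 2 of the 3 values shown sit.

On these data alone, the value of compound 1 is a limit, so the full size of the step stays open. Also open, as far as these compounds go, is whether a still longer chain, or an amine or a carboxylic acid on the chain, would shift the number further.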